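Hydroxy to amino on the aromatic ring of compound 1

A few compounds are considered here, and "the series" means these few. Any claim that something is new, unique, unknown or untested is made for them only; others in the source may bear on it.

Compound 1 `CC[C@]1(c2cccc(O)c2)OC[C@H]([C@@H]2CCCCN2)O1` gives 489 nM in a functional assay (brain) for displacement of a labelled ligand, with Rattus norvegicus as the target (a lower number here means a stronger inhibitor, a higher number a weaker inhibitor), the lowest of the two numbers recorded so far. Compound 2 `CC[C@]1(c2ccc(O)cc2)OC[C@H]([C@@H]2CCCCN2)O1` gives 19900 nM in this assay, a number well beyond the scatter from compound 1. Compound 3 `CC[C@]1(c2cccc(N)c2)OC[C@H]([C@@H]2CCCCN2)O1` is not yet measured. The change from compound 1 to compound 3 is amino in place of hydroxy on an aromatic carbon. Going by the values given here, no measured pair shows this change, so its size in this assay is unknown; a moderate step toward a weaker inhibitor is expected. Compound 3 is estimated at 1500 nM, within 400 nM to 6000 nM, which means an expected step of a 3.1-fold higher number from compound 1 to compound 3 (0.49 log units; beyond the scatter).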

Compound 3, inhibition constant: 1230 nM
The estimate for compound 3 lay 1.2-fold (0.09 log units) above the measured number, within the range that was stated.
By their numbers in this assay, from the lowest: compound 1; then compound 3; then compound 2.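

In this assay, amino in place of hydroxy on this aromatic carbon gives a 2.5-fold higher number from compound 1 to compound 3 (0.40 log units; beyond the scatter), the first step read at this position. The hydroxy can therefore be exchanged for amino, which is counted with the same hydrogen-bond donor and acceptor, at only a modest cost in this series. No available measurement bears on the origin of this step. Still open, going by these compounds, is how a methoxy group, a fluorine atom or a carboxylic acid on the same aromatic carbon would compare with hydroxy and amino in this assay.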